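The source may report more compounds than this note shows. Statements on the series, on what has been measured and on what is new or still open speak of the compounds shown alone.

Going by the values given here, in a physicochemical assay for solubility, read by nephelometry, at pH 7.4 (a lower number here means a less soluble compound, a higher number a more soluble compound), compound 2 (`COc1cccc(NC(=O)c2nnn(Cc3ccccc3)c2N)c1`) gives 16000 nM, the lower of the two numbers so far, while compound 1 (`COc1cccc(NC(=O)c2nnn(Cc3ccc(C#N)cc3)c2N)c1`) gives 216000 nM. Compound 3 (`COc1cccc(NC(=O)c2nnn(Cc3ccc(SC)cc3)c2N)c1`) has methylsulfanyl in place of hydrogen on an aromatic carbon, para to a large group: methylsulfanyl in place of hydrogen on an aromatic carbon. Among the compounds with values here, the only measured step bearing on this is a 14-fold lower number from compound 1 to compound 2 (1.13 log units; beyond the scatter), which is large and beyond the scatter. Within the data shown here, it involves cyano, and no measured compound carries methylsulfanyl, so it is a weak guide. The expected change is a 1.6-fold lower number from compound 2 to compound 3 (0.20 log units; within the scatter), slightly downward and within the scatter. The estimated value for compound 3 is 10000 nM, with an expected range of 3000 nM to 30000 nM.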

Compound 3, solubility: < 12000 nM
Compound 3: no number, only a limit; the forecaster's own chance of this, stated with the estimate: 10%; the middle value does not contradict the limit.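

In this assay compound 3 gives < 12000 nM, which is a limit of the assay and not a number. Replacing cyano with methylsulfanyl at this position gives an at least 18-fold lower number from compound 1 to compound 3 (1.25 log units; beyond the scatter), so the high reading of the nitrile compound does not carry over to this second substituent. Replacing hydrogen with methylsulfanyl gives an at least 1.3-fold lower number from compound 2 to compound 3 (0.12 log units; that floor lies within the scatter), a floor within the scatter, so the two compounds cannot be ordered on this evidence.

As far as these compounds go, the actual level of compound 3 stays open. Also open, from the compounds shown here alone, is whether a carboxylic acid or an amine at this position would read nearer compound 1 or compound 2.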